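The source may report more compounds than this note shows. Statements on the series, on what has been measured and on what is new or still open speak of the compounds shown alone.

Measured in a functional assay on the whole organism for agonist activity, with Mus musculus as the target; a lower number here means that less compound is needed, a higher number that more compound is needed for the effect:
- compound 1 (`CN(C)CC#CCN1CCNC1=O`): 9.7 mg/kg
- compound 2 (`CN1CCN(CC#CCn2ccnc2)C1=O`): 1.4 mg/kg
- compound 3 (`Cc1cncn1CC#CCN1CCN(C)C1=O`): 14 mg/kg

Of these three, compound 2 has the lowest number in this assay, and the values of the other two lie beyond the scatter from it. Compound 4 (`CN(C)CC#CCN1CCN(C)C1=O`) has not yet been measured. It departs from compound 2 in one place, with dimethylamino in place of 1H-imidazol-1-yl on a saturated chain carbon bound to a triple-bonded carbon.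

Among the measured compounds shown here, no measured pair isolates this exchange, so the evidence is indirect. For the measured compounds named here, the one measured step, a 10-fold higher number from compound 2 to compound 3 (1.00 log units; beyond the scatter), comes from methyl in place of hydrogen on an aromatic carbon. It shows that even a small edit to the 1H-imidazol-1-yl group of compound 2 can raise the number. Compound 1 also carries dimethylamino, though its core is not that of compound 2, and compound 1 gives 9.7 mg/kg. A higher number than that of compound 2 is therefore expected in this assay, by somewhat less than the step to compound 3, although the range must stay wide. The expected change is a 4.3-fold higher number from compound 2 to compound 4 (0.63 log units; beyond the scatter). For compound 4 the estimated value is 6 mg/kg, with an expected range from 1.5 mg/kg to 22 mg/kg.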

Compound 4, dose for half-maximal effect: 0.54 mg/kg
For compound 4 the middle estimate is 11-fold (1.05 log units) above the measured one, outside the stated range (below it).
By their numbers in this assay, from the lowest: compound 4; then compound 2; then compounds 1 and 3 (each within the scatter of the next).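

In this assay the exchange of 1H-imidazol-1-yl for dimethylamino on a saturated chain carbon bound to a triple-bonded carbon gives a 2.6-fold lower number from compound 2 to compound 4 (0.41 log units; beyond the scatter) and so shows that this place does not need the aromatic ring: a group with no ring and fewer heavy atoms gives a lower number, whereas the only earlier edit here had raised it. Methyl in place of hydrogen on an amide-type nitrogen in a ring gives an 18-fold lower number from compound 1 to compound 4 (1.25 log units; beyond the scatter) and shows that compound 1, at 9.7 mg/kg, was a poor guide to dimethylamino on the core of compound 2, since the two compounds carry the same amine and differ at that ring nitrogen. Nothing available here accounts for either step.

From the compounds shown here alone, it remains open whether the lower number is particular to dimethylamino or also holds for other amines at this place, such as diethylamino or pyrrolidin-1-yl. Also open, going by these compounds, is whether an ethyl group on the ring nitrogen would serve as well as the methyl of compound 4.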